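Methoxy for ethyl on the benzamide ring of compound 3

A few compounds are considered here, and "the series" means these few. Any claim that something is new, unique, unknown or untested is made for them only; others in the source may bear on it.

Of the compounds shown here, three have been measured in an assay on isolated protein for inhibition of Rho-associated protein kinase 2 (Homo sapiens), read by scintillation counting, radiometric assay and 33P incorporation, with a stated time of 40 min, in the presence of a further agent that is not named here; on this read-out higher numbers stand for weaker inhibition and lower numbers for stronger inhibition. Compound 1 `COc1ccc(OCC(=O)Nc2cccc(NC(=O)c3ccc(N(C)C)cc3)c2)cc1F` gives 652 nM, compound 2 `O=C(COc1ccc2c(=O)ccoc2c1)Nc1cccc(NC(=O)c2ccccc2)c1` gives 16 nM, and compound 3 `CCc1ccc(C(=O)Nc2cccc(NC(=O)COc3ccc4c(=O)ccoc4c3)c2)cc1` gives 24 nM. On these numbers compound 3 stands second highest of the three; its nearest neighbour is compound 2, whose number is within the scatter of its own, and the furthest is compound 1, whose number lies well beyond it.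

Compound 4 `COc1ccc(C(=O)Nc2cccc(NC(=O)COc3ccc4c(=O)ccoc4c3)c2)cc1` differs from compound 3 in one place: methoxy in place of ethyl on an aromatic carbon. Within the data shown here, only one measured step touches the same position, namely a 1.5-fold higher number from compound 2 to compound 3 (0.18 log units; within the scatter), which put ethyl in place of hydrogen on that aromatic carbon and stayed within the scatter. Compound 1 also carries a group at that position, but its other half differs as well, so its value cannot be read as a step. Among the measured compounds shown here, from the single relevant step the substituent at this position appears to matter little, and for compound 4 no change beyond the scatter is expected in this assay, giving an expected step of a 1.2-fold lower number from compound 3 to compound 4 (0.08 log units; within the scatter).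

Compound 4 is therefore estimated at 20 nM, with a range from 9 nM to 45 nM.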

Compound 4, half-maximal inhibitory concentration: 7 nM
The estimate for compound 4 lay 2.9-fold (0.46 log units) above the measured number; the whole stated range lies above it.
By their numbers in this assay, from the lowest: compound 4; then compounds 2 and 3 (each within the scatter of the next); then compound 1.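

In this assay, the group on this aromatic carbon proves not to be indifferent, as the earlier single step had suggested: ethyl in place of hydrogen gave only a 1.5-fold higher number from compound 2 to compound 3 (0.18 log units; within the scatter), whereas methoxy in place of ethyl gives a 3.4-fold lower number from compound 3 to compound 4 (0.54 log units; beyond the scatter), and methoxy in place of hydrogen gives a 2.3-fold lower number from compound 2 to compound 4 (0.36 log units; beyond the scatter). Ethyl and methoxy have the same count of heavy atoms, yet they are not interchangeable here, and of the three groups compared on this carbon in the shared core, only methoxy moves the number beyond the scatter from hydrogen, by a modest step. Nothing available bears on what lies behind this difference.

The compounds shown leave open whether the lower number is tied to methoxy alone or would also appear with ethoxy, hydroxyl or a primary amine on the same carbon. Compound 1 also carries a group there but differs elsewhere in its structure too, so they also leave open whether methoxy would give a similar step on a different core.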